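The source may hold more compounds than are shown below. What is called first, only, known or untested is meant among the compounds shown, and "the series" means these compounds.

Of the compounds shown here, two have been measured so far in a functional assay on PC-3 cells (Homo sapiens) for cytotoxicity, read by MTT assay, with a stated time of 72 h; a lower number here means a stronger inhibitor, a higher number a weaker inhibitor. Compound 2 `O=C(N/N=C/c1cc(Br)c(O)c(Br)c1)Nc1cc2c(Nc3ccc(F)c(Cl)c3)ncnc2cc1O[C@H]1CCOC1` gives 6160 nM, and compound 1 `O=C(N/N=C/c1ccc(O)c(Br)c1)Nc1cc2c(Nc3ccc(F)c(Cl)c3)ncnc2cc1O[C@H]1CCOC1` gives 5230 nM; the two numbers lie within the scatter of each other, the step being a 1.2-fold higher number from compound 1 to compound 2 (0.07 log units; within the scatter). Compound 3 `COc1cc2ncnc(Nc3ccc(F)c(Cl)c3)c2cc1NC(=O)N/N=C/c1cc(Br)c(O)c(Br)c1` differs from compound 2 by methyl in place of oxolan-3-yl on an oxygen on an aromatic ring. Among the compounds with values here, the only measured step concerns a bromo group on a different part of the molecule, so it gives no direct guide to this change. Compound 3 is therefore expected to stay close to compound 2, estimated at 6000 nM with a range from 2500 nM to 15000 nM, a step of a 1.0-fold lower number from compound 2 to compound 3 (0.01 log units; within the scatter) expected within the scatter.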

Compound 3, half-maximal inhibitory concentration: 41500 nM
Compound 3: middle estimate off by 6.9-fold (0.84 log units), on the low side; the whole stated range lies below it.
By their numbers in this assay, from the lowest: compounds 1 and 2 (each within the scatter of the next); then compound 3.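

Replacing oxolan-3-yl with methyl on this oxygen in this assay gives a 6.7-fold higher number from compound 2 to compound 3 (0.83 log units; beyond the scatter) and so moves the number beyond the scatter, which the earlier bromo step did not do. This position therefore responds to the group it carries, and of these two compounds, the one with oxolan-3-yl has the lower number. Nothing available here explains this step.

Going by these compounds, it remains open where an ethyl group or a longer chain ending in an amine would fall relative to compound 2 and compound 3. On these data alone, it is also open whether the same change would give a similar step with the other aromatic ring of compound 1.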